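Swapping an Ether Amide for a Urea in Cytotoxicity

A few compounds are considered here, and "the series" means these few. Any claim that something is new, unique, unknown or untested is made for them only; others in the source may bear on it.

Of the compounds shown here, two sharing one core have been tested in an ADME assay on Vero cells (Chlorocebus sabaeus) for cytotoxicity, read by resazurin assay, with a stated time of 3 days; on this read-out lower numbers stand for stronger inhibition and higher numbers for weaker inhibition. Compound 1 `CCCCNC(=O)Nc1cc2nc(C3CCCCC3)[nH]c2cc1N(CC)CC` reached only a limit of the assay, giving > 100 ug/mL. Compound 2 `CCCOCC(=O)Nc1cc2nc(C3CCCCC3)[nH]c2cc1N(C)C` likewise stopped at a limit, giving < 50 ug/mL. Compound 3 `CCCCNC(=O)Nc1cc2nc(C3CCCCC3)[nH]c2cc1N(C)C` is compound 2 with butylamino in place of propoxymethyl on a carbonyl carbon, the same butylcarbamoyl group that compound 1 carries. Going by the values given here, with no measured step between the two known compounds, only a modest shift is expected, and the step of an at least 1.6-fold higher number from compound 2 to compound 3 (0.20 log units; that floor lies within the scatter) is estimated as a drift toward weaker inhibition. Compound 3 is expected to give about 80 ug/mL, within 30 ug/mL to 200 ug/mL.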

Compound 3, half-maximal inhibitory concentration: > 100 ug/mL
Compound 3 gave a limit, no number (the forecaster's own chance of this, stated with the estimate: 60%); middle value at least 1.2-fold (0.09 log units) from the limit.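

In this assay putting butylamino in place of propoxymethyl on a carbonyl carbon gives an at least 2.0-fold higher number from compound 2 to compound 3 (0.30 log units; that floor lies within the scatter) as the size of the change, so only a lower bound on this swap is known. With butylamino kept, compound 3 and compound 1 both stop at a limit of the assay, so the step from diethylamino to dimethylamino on an aromatic carbon cannot be read: the limit of > 100 ug/mL in this assay, at which 2 of the 3 values shown sit. From the compounds shown here alone, how far the step from propoxymethyl to butylamino truly reaches remains open. Also open, going by these compounds, is how a longer chain such as hexylamino, or a chain ending in a carboxylic acid, would behave on that carbonyl carbon.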